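Fluorine position on the side-chain phenyl, compound 3 to 4

The source may report more compounds than this note shows. Statements on the series, on what has been measured and on what is new or still open speak of the compounds shown alone.

In a functional assay on 1321-N1 cells for agonist activity at P2Y purinoceptor 6 (Homo sapiens), read by scintillation counting and inositol phosphate accumulation (a higher number here means that more compound is needed for the effect, a lower number that less compound is needed), compound 1 `O=c1[nH]/c(=N\OCCCCc2ccccc2)ccn1[C@@H]1O[C@H](COP(=O)(O)OP(=O)(O)OP(=O)(O)O)[C@@H](O)[C@H]1O` gives 251 nM. In this assay compound 2 `O=c1[nH]/c(=N\OCCOc2ccccc2)ccn1[C@@H]1O[C@H](COP(=O)(O)OP(=O)(O)OP(=O)(O)O)[C@@H](O)[C@H]1O` gives 1780 nM. In this assay compound 3 `O=c1[nH]/c(=N\OCCCc2cccc(F)c2)ccn1[C@@H]1O[C@H](COP(=O)(O)OP(=O)(O)OP(=O)(O)O)[C@@H](O)[C@H]1O` gives 539 nM, the second highest of the three numbers; its nearest neighbour stands at a 2.1-fold higher number from compound 1 to compound 3 (0.33 log units; beyond the scatter) and its furthest at a 3.3-fold lower number from compound 2 to compound 3 (0.52 log units; beyond the scatter). Compound 4 `O=c1[nH]/c(=N\OCCCc2ccc(F)cc2)ccn1[C@@H]1O[C@H](COP(=O)(O)OP(=O)(O)OP(=O)(O)O)[C@@H](O)[C@H]1O` differs from compound 3 by 4-fluorophenyl in place of 3-fluorophenyl on a saturated chain carbon, three bonds along the chain from an oxygen. For the measured compounds named here, no measured step compares 3-fluorophenyl with 4-fluorophenyl; the two steps that reach compound 3 exchange the whole chain end and only set the scale of the series. The step of a 1.1-fold lower number from compound 3 to compound 4 (0.03 log units; within the scatter) is therefore expected to stay within the scatter. For compound 4 the estimate in this assay is 500 nM, with a range of 200 nM to 1300 nM.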

Compound 4, half-maximal effective concentration: 1210 nM
For compound 4 the middle estimate is 2.4-fold (0.38 log units) below the measured one; measured number inside the range.
By their numbers in this assay, from the lowest: compound 1; then compound 3; then compounds 4 and 2 (each within the scatter of the next).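

Exchanging 3-fluorophenyl for 4-fluorophenyl on the same chain is not a silent change in this assay (a 2.2-fold higher number from compound 3 to compound 4 (0.35 log units; beyond the scatter)), so the place of the fluorine on the phenyl ring matters in this series. The 4-fluorophenyl end also stays apart from the unfluorinated chain of compound 1 (a 4.8-fold higher number from compound 1 to compound 4 (0.68 log units; beyond the scatter)), yet it cannot be separated from the phenoxy end (a 1.5-fold lower number from compound 2 to compound 4 (0.17 log units; within the scatter)). Nothing available explains the effect of moving the fluorine. From the compounds shown here alone, whether a chlorophenyl or methoxyphenyl group would behave like either fluorophenyl group stays open, as does whether a longer chain would keep the gap between them.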